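A few compounds are considered here, and "the series" means these few. Any claim that something is new, unique, unknown or untested is made for them only; others in the source may bear on it.

Compound 1 `CCCCC(O)CC(=O)O[C@H](CC=C(C)C)C1=CC(=O)c2c(O)ccc(O)c2C1=O`: 72200 nM
Compound 2 `CC(C)=CC[C@@H](OC[C@H](C)O)C1=CC(=O)c2c(O)ccc(O)c2C1=O`: 40300 nM

Both compounds share the same core and were tested in a functional assay on HeLa cells (Homo sapiens) for cytotoxicity, read by MTT assay; on this read-out lower numbers stand for stronger inhibition and higher numbers for weaker inhibition. Compound 1 gives 72200 nM and compound 2 gives 40300 nM. Compound 2 holds the smaller of the two numbers, yet the step of a 1.8-fold lower number from compound 1 to compound 2 (0.25 log units; within the scatter) lies within the scatter, so the two compounds cannot be told apart on this read-out.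

Compound 3 `CC(C)=CC[C@@H](OC(=O)C1CCCCO1)C1=CC(=O)c2c(O)ccc(O)c2C1=O` is not yet measured. It differs from compound 2 at a single spot: (oxan-2-yl)carbonyl in place of 2-hydroxypropyl on an oxygen on a saturated carbon. Within the data shown here, the one measured step, from compound 1 to compound 2, changed the group on the same oxygen, exchanging a (2-hydroxyhexyl)carbonyl for a 2-hydroxypropyl, and gave only a 1.8-fold lower number from compound 1 to compound 2 (0.25 log units; within the scatter). Compound 3 returns to a carbonyl-bearing group on that oxygen, now carrying a six-membered non-aromatic ring and no hydrogen-bond donor. Among the measured compounds shown here, with only one step to lean on, and that step within the scatter, no shift beyond the scatter is expected in this assay. Compound 3 is therefore estimated at 55000 nM, with a range from 20000 nM to 150000 nM, an expected step of a 1.4-fold higher number from compound 2 to compound 3 (0.14 log units; within the scatter).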

Compound 3, half-maximal inhibitory concentration: > 100000 nM
Compound 3: a limit, no number (the forecaster's own chance of this, stated with the estimate: 10%); middle value at least 1.8-fold (0.25 log units) away from the limit.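

At the oxygen on a saturated carbon, the first measured change could not be told from the scatter, but the change to (oxan-2-yl)carbonyl gives an at least 2.4-fold higher number from compound 2 to compound 3 (0.39 log units; beyond the scatter) in this assay, so the group on this oxygen can shift the read-out by more than repeated measurements would. Keeping the carbonyl and replacing 2-hydroxyhexyl with oxan-2-yl gives an at least 1.3-fold higher number from compound 1 to compound 3 (0.14 log units; that floor lies within the scatter), and as that floor lies within the scatter, no order can be stated between these two compounds. As far as these compounds go, compound 3 carries a limit of the assay and not a number, so both of its steps give only a minimum size and the full size of each stays unknown: the limit of > 100000 nM in this assay, at which 1 of the 3 values shown sits.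

Compound 2 and compound 3 differ in both the carbonyl and the ring, so the data cannot say whether either one alone accounts for the step. From the compounds shown here alone, it also remains open how this assay would respond to an amine, a carboxylic acid or a longer chain on this oxygen, and whether any such group would give a lower number than those seen so far.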